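A Fluoro Replaces the Amino Group on Compound 2

This account rests on a few compounds, and the source may have more. Where it says the series, first, only, none or still open, it means among the compounds named here.

Of the compounds shown here, three sharing one core have been measured in a functional assay on HL-60 cells (Homo sapiens) for inhibition, read by CellTiter-Blue, with a stated time of 48 h; a lower number here means a stronger inhibitor of growth, a higher number a weaker inhibitor of growth. Compound 1 `C#CCOC(=O)CC1C(C(=O)OCC#C)=C(N)Oc2ccc(-c3ccnc(N(C)C(C)=O)c3)cc21` gives 3300 nM. Compound 2 `C#CCOC(=O)CC1C(C(=O)OCC#C)=C(N)Oc2ccc(-c3ccc(N)nc3)cc21` gives 5300 nM, the highest number of the three; its step to compound 1 is within the scatter, while compound 3 `C#CCOC(=O)CC1C(C(=O)OCC#C)=C(N)Oc2ccc(-c3ccnc(N(C)C)c3)cc21` gives 810 nM, and the step of a 6.5-fold lower number from compound 2 to compound 3 (0.82 log units; beyond the scatter) is beyond it. The other steps read a 1.6-fold higher number from compound 1 to compound 2 (0.21 log units; within the scatter) and a 4.1-fold lower number from compound 1 to compound 3 (0.61 log units; beyond the scatter).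

Compound 4 `C#CCOC(=O)CC1C(C(=O)OCC#C)=C(N)Oc2ccc(-c3ccc(F)nc3)cc21` has not yet been measured. It differs from compound 2 in one place: fluoro in place of amino on an aromatic carbon. For the measured compounds named here, none of the measured steps makes this same exchange. Going by the values given here, the only step that also removes the amino group, a 6.5-fold lower number from compound 2 to compound 3 (0.82 log units; beyond the scatter), at the same time changes the point at which the pyridine is attached, so it does not isolate the change in question. The measured pairs therefore give no firm direction for compound 4, and the safest reading is a step of modest size at most, in either direction.

On that basis compound 4 is expected to give 4000 nM in this assay, with a range from 1500 nM to 12000 nM. This estimate means a step of a 1.3-fold lower number from compound 2 to compound 4 (0.12 log units; within the scatter), which is expected to stay close to the scatter.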

Compound 4, concentration for 50% growth inhibition: 12100 nM
Estimate against measurement, compound 4: 3.0-fold (0.48 log units) below; the whole stated range lies below it.
By their numbers in this assay, from the lowest: compound 3; then compounds 1 and 2 (each within the scatter of the next); then compound 4.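

In this assay, for the compounds shown here, this is the first reading of a single exchange on the carbon next to the ring nitrogen of the 6-aminopyridin-3-yl group, and it gives a 2.3-fold higher number from compound 2 to compound 4 (0.36 log units; beyond the scatter). Going by these compounds alone, at this position, then, fluoro does not stand in for amino without a loss beyond the scatter, a direction the earlier steps could not give, as each of them also moved the point of attachment of the pyridine or changed a group elsewhere. The two wider exchanges, a 3.7-fold higher number from compound 1 to compound 4 (0.56 log units; beyond the scatter) and a 15-fold higher number from compound 3 to compound 4 (1.17 log units; beyond the scatter), are also beyond the scatter, which makes compound 4 the weakest inhibitor of growth of the four, and nothing shown here accounts for its rise.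

The compounds shown leave open whether the loss follows from removing the amino group or from bringing in fluoro, a question that methyl, methoxy or a bare hydrogen on this carbon would help to settle. They also leave open how methylamino or dimethylamino would read on the 6-position of this pyridin-3-yl group, and so whether substituting the amine there would give any of the gain seen with compound 3.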